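Aryl Swap at the Thiophene Core: a Pyridine Variant

A few compounds are considered here, and "the series" means these few. Any claim that something is new, unique, unknown or untested is made for them only; others in the source may bear on it.

Measured so far:
Compound 1, `COc1cc(C(=O)c2sc(-c3ccc(C)cc3)cc2N)cc(OC)c1OC`, 15 nM
Compound 2, `COc1cc(C(=O)c2sc(-c3cccs3)cc2N)cc(OC)c1OC`, 9.4 nM
Compound 3, `COc1cc(C(=O)c2sc(-c3ccc([N+](=O)[O-])cc3)cc2N)cc(OC)c1OC`, 99 nM

In a functional assay on CCRF-CEM cells (Homo sapiens) for antiproliferative activity (on this read-out higher numbers stand for weaker inhibition and lower numbers for stronger inhibition), compound 1 stands second highest of the three numbers. Its nearest neighbour is compound 2, with a 1.6-fold lower number from compound 1 to compound 2 (0.20 log units; within the scatter), a step within the scatter. Its furthest is compound 3, with a 6.6-fold higher number from compound 1 to compound 3 (0.82 log units; beyond the scatter), and from compound 2 the same end point gives an 11-fold higher number from compound 2 to compound 3 (1.02 log units; beyond the scatter).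

The unmeasured compound 4, `COc1cc(C(=O)c2sc(-c3ccncc3)cc2N)cc(OC)c1OC`, differs from compound 1 in one place: pyridin-4-yl in place of 4-methylphenyl on an aromatic carbon. For the measured compounds named here, two measured steps bear on this. The swap of the whole ring for a five-membered heteroaromatic in a 1.6-fold lower number from compound 1 to compound 2 (0.20 log units; within the scatter) changed nothing beyond the scatter, whereas placing a hydrogen-bond-accepting substituent on the six-membered ring in a 6.6-fold higher number from compound 1 to compound 3 (0.82 log units; beyond the scatter) cost a modest amount. Compound 4 keeps a six-membered ring but brings in an acceptor, so a modest weakening in this assay is expected, likely smaller than that seen for compound 3 because a 6.6-fold higher number from compound 1 to compound 3 (0.82 log units; beyond the scatter) involved a nitro group and not a ring nitrogen.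

For compound 4 the expected value in this assay is 35 nM, between 12 nM and 110 nM, which would mean a 2.3-fold higher number from compound 1 to compound 4 (0.37 log units; beyond the scatter).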

Compound 4, half-maximal inhibitory concentration: 110 nM
For compound 4 the middle estimate is 3.1-fold (0.50 log units) below the measured one; low and high end bracket the measured number.
By their numbers in this assay, from the lowest: compounds 2 and 1 (each within the scatter of the next); then compounds 3 and 4 (each within the scatter of the next).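

On the aromatic carbon next to the ring sulfur, pyridin-4-yl in place of 4-methylphenyl gives a 7.3-fold higher number from compound 1 to compound 4 (0.87 log units; beyond the scatter) in this assay, and the replacement of 4-nitrophenyl by the same ring gives a 1.1-fold higher number from compound 3 to compound 4 (0.05 log units; within the scatter) and so cannot be told apart from it. A ring nitrogen alone, with no substituent on the ring, thus puts compound 4 level with compound 3. A hetero atom in the ring does not settle the outcome, since compound 2, with its ring sulfur, stays within the scatter of compound 1, while pyridin-4-yl against thiophen-2-yl gives a 12-fold higher number from compound 2 to compound 4 (1.07 log units; beyond the scatter) in this same read-out.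

As far as these compounds go, whether the loss depends on where the nitrogen sits, as pyridin-3-yl would show, or extends to 4-aminophenyl or 4-methoxyphenyl, stays open. No measurement here explains why these compounds fall into two groups.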